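The source may report more compounds than this note shows. Statements on the series, on what has been measured and on what is new or still open speak of the compounds shown alone.

In a functional assay on Ehrlich cells (Mus musculus) for cytotoxicity, read by trypan blue exclusion, with a stated time of 2 h (on this read-out higher numbers stand for weaker inhibition and lower numbers for stronger inhibition), compound 1 (`N#CC1=C(NC(=O)/C=C/c2ccccc2)N(c2ccc(S(N)(=O)=O)cc2)C2=C(C(=O)CCC2)C1c1ccc(Cl)cc1Cl`) gives > 100 ug/mL, which is a limit of the assay and not a number. Compound 3 (`NC(=O)C1=C(N)N(c2ccc(S(N)(=O)=O)cc2)C2=C(C(=O)CCC2)C1c1ccc(Cl)cc1Cl`) gives > 100 ug/mL, which is also a limit. Compound 1 therefore stands at the limit of > 100 ug/mL in this assay, at which 2 of the 3 values shown sit. Compound 2 (`COc1cc(C(=O)NC2=C(C#N)C(c3ccc(Cl)cc3Cl)C3=C(CCCC3=O)N2c2ccc(S(N)(=O)=O)cc2)cc(OC)c1OC`) gives a measured number, 60 ug/mL.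

Compound 4 (`CCO/C=N/C1=C(C#N)C(c2ccc(Cl)cc2Cl)C2=C(CCCC2=O)N1c1ccc(S(N)(=O)=O)cc1`) has not yet been measured. It gives up the ((2-phenylethenyl)carbonyl)amino group of compound 1: a group of 5 heavy atoms (3 carbon, 1 nitrogen, 1 oxygen; no ring) in place of a group of 11 heavy atoms (9 carbon, 1 nitrogen, 1 oxygen; one six-membered aromatic ring of carbon only), on a double-bonded ring carbon. Within the data shown here, one measured step bears on this, an at least 1.6-fold lower number from compound 1 to compound 2 (0.22 log units; that floor lies within the scatter). It alters the same group, but only on its carbonyl carbon, and its floor lies within the scatter, so it is a weak guide to a larger replacement. It suggests that changes at this place may bring a lower number, but it does not show one beyond the scatter. The expected change in this assay is therefore modest, and the estimated step is an at least 1.2-fold lower number from compound 1 to compound 4 (0.09 log units; that floor lies within the scatter), not clearly beyond the scatter. For compound 4 the estimated value is 80 ug/mL, with an expected range from 30 ug/mL to 200 ug/mL.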

Compound 4, half-maximal inhibitory concentration: > 100 ug/mL
Compound 4: a limit, no number; the forecaster's own chance of this, stated with the estimate: 45%; middle value at least 1.2-fold (0.09 log units) away from the limit.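

Compound 1 and compound 4 both stop at a limit of this assay and not at a number, so the step between them cannot be read. From the compounds shown here alone, it stays open whether replacing the ((2-phenylethenyl)carbonyl)amino group of compound 1 with the group in compound 4 changes the read-out at all.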